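Working notes: fluoro to hydrogen on the aryl ring of compound 2

The compounds below may be only part of what the source reports. "The series", "measured", "known", "first", "only" and "open" are said of these compounds alone.

Measured so far:
compound 1 `CN(C)C(=S)N/N=C/c1ccc2cccnc2n1` — 630 nM
compound 2 `Fc1ccccc1NC(=S)N/N=C/c1ccc2ccccc2n1` — > 100000 nM
compound 3 `NC(=S)N/N=C/c1cnc2ccccc2n1` — > 100000 nM

For the measured compounds named here, in a functional assay on SGC-7901 cells (Homo sapiens) for antiproliferative activity, read by sulforhodamine B assay, with a stated time of 72 h (on this read-out higher numbers stand for weaker inhibition and lower numbers for stronger inhibition), compound 1 gives 630 nM, the only numerical value in the set. For compound 2 the assay reports only a limit, > 100000 nM. For compound 3 the assay likewise reports only a limit, > 100000 nM. Compound 2 therefore stands at the limit of > 100000 nM in this assay, at which 2 of the 3 values shown sit, a position it shares with compound 3, and no number separates it from compound 3; only compound 1 lies clearly apart from both.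

Compound 4 `S=C(N/N=C/c1ccc2ccccc2n1)Nc1ccccc1` differs from compound 2 by hydrogen in place of fluoro on an aromatic carbon. Going by the values given here, no pair of measured compounds differs in this one place, so the set gives no measured step for this change, and the three measured values offer no handle on which way it acts. Given that compound 2 sits at the limit, the expected step in this assay is none beyond the scatter, with the outcome most likely again a limit rather than a number. Compound 4 is expected to give 100000 nM, in a range from 30000 nM to 300000 nM. The expected step from compound 2 to compound 4 is thus a number no higher from compound 2 to compound 4 (the limit leaves the size open).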

Compound 4, half-maximal inhibitory concentration: 26500 nM
For compound 4 the middle estimate is 3.8-fold (0.58 log units) above the measured one, and the stated range ends above it.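

In this assay, hydrogen in place of fluoro on the aromatic carbon, ortho to a large group, gives compound 4 a measured number, 26500 nM, and an at least 3.7-fold lower number from compound 2 to compound 4 (0.57 log units; beyond the scatter) shows that this one place can alter the read-out beyond the scatter. Compound 2 gives > 100000 nM, which is a limit of the assay and not a number. Because compound 2 sits at this limit, the step fixes only a bound on the size of the change and not the size itself: the limit of > 100000 nM in this assay, at which 2 of the 4 values shown sit.

Only fluoro and hydrogen are shown at this place, so it remains open whether chloro, methoxy or an amine there would give a lower number than compound 4 or return the read-out to the limit, and whether the same place elsewhere on the phenyl ring would respond in the same way. No single change links compound 4 to compound 1 or compound 3, so these compounds give no step to compound 4, and the data shown assign no cause to the step.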